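The compounds below may be only part of what the source reports. "The series", "measured", "known", "first", "only" and "open" are said of these compounds alone.

Working notes on the series. The shared core of compound 2 `CCC(C)(C)Cc1c[nH]c(CCc2ccc(-c3cnccn3)cc2)n1` carries a pyrazin-2-yl group on the aromatic carbon; in a functional assay on HEK293 cells for agonist activity at Bombesin receptor subtype-3 (Homo sapiens), read by luminescence and calcium flux, with a stated time of 10 min (on this read-out higher numbers stand for an effect only at larger amounts of compound and lower numbers for an effect already at smaller amounts), compound 2 gives 431 nM, the second highest of three numbers. Compound 1 `CCC(C)(C)Cc1c[nH]c(CCc2ccc(-c3csnn3)cc2)n1`, with 1,2,3-thiadiazol-4-yl at the same place, gives 538 nM, and compound 3 `CCC(C)(C)Cc1c[nH]c(CCc2ccc(-c3cnsc3)cc2)n1`, with 1,2-thiazol-4-yl there, gives 44 nM. The measured steps at this position are a 1.2-fold lower number from compound 1 to compound 2 (0.10 log units; within the scatter), a 12-fold lower number from compound 1 to compound 3 (1.09 log units; beyond the scatter) and a 9.8-fold lower number from compound 2 to compound 3 (0.99 log units; beyond the scatter), so swapping one small heteroaromatic ring for another has moved the number from nothing up to a large step.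

Compound 4 `CCC(C)(C)Cc1c[nH]c(CCc2ccc(-c3cccnc3C(=O)O)cc2)n1` differs from compound 2 by 2-carboxypyridin-3-yl in place of pyrazin-2-yl on an aromatic carbon. Within the data shown here, no measured step shows a carboxylic acid entering at this position, so the direction is open; the exchanges measured so far bracket a range from no change to a large change, and the group entering here is the largest yet. The number for compound 4 is expected near that of compound 2 , with a wide range: 600 nM, between 150 nM and 2500 nM, which as a step means a 1.4-fold higher number from compound 2 to compound 4 (0.14 log units; within the scatter) is expected.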

Compound 4, half-maximal effective concentration: 1260 nM
Estimate against measurement, compound 4: 2.1-fold (0.32 log units) below, and the stated range covers the measured number.
By their numbers in this assay, from the lowest: compound 3; then compounds 2 and 1 (each within the scatter of the next); then compound 4.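

In this assay, the exchange to 2-carboxypyridin-3-yl gives a higher number against each earlier ring, with two modest steps (a 2.9-fold higher number from compound 2 to compound 4 (0.47 log units; beyond the scatter)) and (a 2.3-fold higher number from compound 1 to compound 4 (0.37 log units; beyond the scatter)) and one large step (a 29-fold higher number from compound 3 to compound 4 (1.46 log units; beyond the scatter)). Compound 4 therefore has the highest number of the four, and this position admits a group with a carboxylic acid and a hydrogen-bond donor at the cost of a modest step from compound 1 or compound 2, while the gain seen with 1,2-thiazol-4-yl is lost. No measurement on hand explains this rise.

The compounds shown do not separate the contribution of the carboxylic acid from that of the pyridine ring that carries it. A plain pyridin-3-yl group, or a methyl ester or primary amide in place of the carboxylic acid, would be needed to make that separation.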